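The source may hold more compounds than are shown below. What is called first, only, known or untested is meant among the compounds shown, and "the series" means these compounds.

Working notes on the series. Going by the values given here, compound 1 `Oc1ccc(-c2cc(-c3cccc(Cl)c3)nc(-c3ccccn3)c2)cc1` and compound 2 `Oc1cccc(-c2cc(-c3ccc(Cl)cc3)nc(-c3cccs3)c2)c1` are the two compounds measured so far in a functional assay on DU-145 cells (Homo sapiens) for cytotoxicity, read by CCK-8 assay and cell counting, with a stated time of 2 days; a lower number here means a stronger inhibitor, a higher number a weaker inhibitor. In this assay compound 1 gives 35200 nM, and compound 2 gives 11600 nM. Compound 2 thus holds the lower of the two numbers, and the gap to compound 1 is beyond the scatter. Compound 3 `Oc1cccc(-c2cc(-c3ccc(Cl)cc3)nc(-c3ccco3)c2)c1` is the next compound, not yet measured. It differs from compound 2 in one place: furan-2-yl in place of thiophen-2-yl on an aromatic carbon. With no measured step of this kind in the series, the expected step from compound 2 to compound 3 in this assay is a 1.2-fold higher number from compound 2 to compound 3 (0.08 log units; within the scatter), none beyond the scatter. Compound 3 is therefore estimated at 14000 nM, with a range from 6000 nM to 35000 nM.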

Compound 3, half-maximal inhibitory concentration: 11400 nM
Compound 3: middle estimate off by 1.2-fold (0.09 log units), on the high side; the range from low to high includes it.
By their numbers in this assay, from the lowest: compounds 3 and 2 (each within the scatter of the next); then compound 1.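

At this position next to the ring nitrogen, furan-2-yl in place of thiophen-2-yl gives a 1.0-fold lower number from compound 2 to compound 3 (0.01 log units; within the scatter) in this assay. Going by these compounds alone, this is the first measured step, and it does not separate the two five-membered aromatic rings, which differ only in carrying oxygen or sulfur as the hetero atom. No measured evidence bears on this result.

On these data alone, what a non-aromatic group, such as an amine or a carboxylic acid, would give on this carbon remains open. Also open, as far as these compounds go, is whether the two rings would still match with a different group in place of the 3-hydroxyphenyl or 4-chlorophenyl group.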